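This account rests on a few compounds, and the source may have more. Where it says the series, first, only, none or still open, it means among the compounds named here.

Notes on the series in an ADME assay on HepG2 cells (Homo sapiens) for cytotoxicity, read by CellTiter-Glo, with a stated time of 48 h; on this read-out lower numbers stand for higher toxicity in this test and higher numbers for lower toxicity in this test: compound 3 `COc1ccc2nc(S(C)(=O)=O)c(NC3CCCCC3)nc2c1` gives 79400 nM, the higher of the two actual numbers so far. The other number belongs to compound 1 `CS(=O)(=O)c1ccc(-c2nc3ccc(Br)cc3nc2-c2ccc(Cl)cc2)cc1`, which gives 2000 nM, well below compound 3 and beyond the scatter. Compound 2 `COc1ccc2nc(S(C)(=O)=O)c(NCCO)nc2c1` reads > 100000 nM, which is a limit of the assay and not a number; this is the limit of > 100000 nM in this assay, at which 1 of the 3 values shown sits.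

The next compound is compound 4 `COc1ccc2nc(S(C)(=O)=O)c(NCCC(C)C)nc2c1`, with isopentyl in place of cyclohexyl on a nitrogen on an aromatic ring. For the measured compounds named here, the same nitrogen carries the only measured step, an at least 1.2-fold lower number from compound 2 to compound 3 (0.10 log units; that floor lies within the scatter). That step is bounded on one side only, and its floor gives no firm size. Compound 1 differs from compound 3 in more than one place, so its value does not bear directly on this change.

With so little to go on, no step beyond the scatter is expected in this assay, and no direction can be favoured. The estimated change is a 1.1-fold lower number from compound 3 to compound 4 (0.05 log units; within the scatter). For compound 4 the expected value is 70000 nM, with an estimated range of 30000 nM to 100000 nM.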

Compound 4, half-maximal cytotoxic concentration: 50100 nM
Beside the measured number, compound 4's estimate is 1.4-fold (0.15 log units) above it, within the range that was stated.
By their numbers in this assay, from the lowest: compound 1; then compounds 4 and 3 (each within the scatter of the next). At a limit, above all of these: compound 2.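

In this assay, the nitrogen on an aromatic ring now has a second carbon-only group to compare: isopentyl, with no ring, in place of cyclohexyl, with one six-membered non-aromatic ring of carbon only, gives a 1.6-fold lower number from compound 3 to compound 4 (0.20 log units; within the scatter), so the ring is not needed to keep the number in this range. Isopropyl in place of hydroxy on the saturated chain gives an at least 1.9-fold lower number from compound 2 to compound 4 (0.30 log units; that floor lies within the scatter), a step bounded on one side only that sets no firm size for this change. Compound 2 reads > 100000 nM, which is a limit of the assay and not a number: the limit of > 100000 nM in this assay, at which 1 of the 4 values shown sits.

On these data alone, whether a different kind of group on this nitrogen, such as an amine or a carboxylic acid at the end of the chain, or a longer chain, would give a step beyond the scatter stays open. For the compounds shown here, also open is whether a phenyl ring on this nitrogen would behave like cyclohexyl, and whether the small step seen here would hold on a core other than the one shared by compounds 2, 3 and 4.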